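Nitro to amino on the benzyl of compound 1

The compounds below may be only part of what the source reports. "The series", "measured", "known", "first", "only" and "open" are said of these compounds alone.

Measured compounds
compound 1 `COC(=O)c1ccc(NCc2cncn2Cc2cccc([N+](=O)[O-])c2)cc1-c1ccccc1` — > 10000 nM in a toxicity assay on NIH3T3 cells (Mus musculus) for cytotoxicity, read by resazurin assay; a higher number here means that more compound is needed for the effect, a lower number that less compound is needed
compound 2 `Cc1ccccc1-c1cc(NCc2cncn2Cc2ccc(-c3ccccc3)cc2)ccc1-c1nc2ccccc2s1` — > 1000 nM
compound 3 `c1ccc(Cn2cncc2CNc2cccc(-c3ccccc3)c2)cc1` — > 750 nM

Compound 1 stands at a limit, not a number: its value of > 10000 nM is the limit (the limit of > 10000 nM in this assay, at which 1 of the 3 values shown sits). Compound 2 is also reported only as a limit, (the limit of > 1000 nM in this assay, at which 1 of the 3 values shown sits). Compound 3 is again a limit, (the limit of > 750 nM in this assay, at which 1 of the 3 values shown sits). All three measured values in this assay are therefore limits, and none of them can be ordered against another; no step between measured compounds is available, and compound 1 cannot be placed above or below the others on the numbers shown.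

Compound 4 `COC(=O)c1ccc(NCc2cncn2Cc2cccc(N)c2)cc1-c1ccccc1` has not been measured. It differs from compound 1 in one place: amino in place of nitro on an aromatic carbon.

Within the data shown here, with every measured compound sitting at a limit, there is no measured step on which to rest a direction for this change. The expectation for this assay is a step from compound 1 to compound 4 of none beyond the scatter, so the estimate is a number no higher from compound 1 to compound 4 (the limit leaves the size open). Compound 4 is expected to give about 10000 nM, with a range from 3000 nM to 30000 nM, and most likely the assay reports a limit again rather than a number.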

Compound 4, half-maximal effective concentration: > 10000 nM
Compound 4 was reported as a limit (the forecaster's own chance of this, stated with the estimate: 80%); the middle value lies on the limit itself.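

No new step can be read between compound 1 and compound 4, since both are reported only as limits in this assay. They share one limit: the limit of > 10000 nM in this assay, at which 2 of the 4 values shown sit.

The compounds shown leave open where any of them would fall as a number in this assay, and whether 3-nitrobenzyl to 3-aminobenzyl shifts the read-out at all.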